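From 2,4-dihydroxybenzyl to carboxy on the shared core

The compounds below may be only part of what the source reports. "The series", "measured", "known", "first", "only" and "open" are said of these compounds alone.

Measured in a functional assay on P388 cells (Mus musculus) for cytotoxicity (a lower number here means a stronger inhibitor, a higher number a weaker inhibitor), for three compounds
Compound 1 `Cc1cc(-c2c(F)cc3c(=O)c(Cc4ccccc4O)cn(C4CC4)c3c2F)cc(C)n1` gives 670 nM
Compound 2 `Cc1cc(-c2c(F)cc3c(=O)c(Cc4ccc[nH]4)cn(C4CC4)c3c2F)cc(C)n1` gives 930 nM
Compound 3 `Cc1cc(-c2c(F)cc3c(=O)c(Cc4ccc(O)cc4O)cn(C4CC4)c3c2F)cc(C)n1` gives 210 nM

Compound 3 has the lowest number of the three, beyond the scatter from both others. Going by the values given here, compound 4 `Cc1cc(-c2c(F)cc3c(=O)c(C(=O)O)cn(C4CC4)c3c2F)cc(C)n1` carries carboxy in place of 2,4-dihydroxybenzyl on an aromatic carbon and no measured compound has carboxy there. The modest steps of a 3.2-fold lower number from compound 1 to compound 3 (0.50 log units; beyond the scatter) and a 4.4-fold lower number from compound 2 to compound 3 (0.65 log units; beyond the scatter) bear on this change, while a 1.4-fold higher number from compound 1 to compound 2 (0.14 log units; within the scatter) stays within the scatter. Each of these steps keeps a ring on the saturated chain carbon, so they guide the expectation only loosely. A higher number is expected, larger than either modest step, with a 14-fold higher number from compound 3 to compound 4 (1.15 log units; beyond the scatter) as the estimated step. Compound 4 is estimated at 3000 nM (range 800 nM to 12000 nM).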

Compound 4, half-maximal inhibitory concentration: 29000 nM
Compound 4: the middle estimate sits 9.7-fold (0.99 log units) below what was measured; measured number above the stated range.
By their numbers in this assay, from the lowest: compound 3; then compounds 1 and 2 (each within the scatter of the next); then compound 4.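

Carboxy in place of the ring-bearing groups on this aromatic carbon gives a 140-fold higher number from compound 3 to compound 4 (2.14 log units; beyond the scatter) and a 43-fold higher number from compound 1 to compound 4 (1.64 log units; beyond the scatter) and a 31-fold higher number from compound 2 to compound 4 (1.49 log units; beyond the scatter) in this assay as the large steps of this series. Among the compounds shown, all three with a ring on the saturated chain carbon have lower numbers than compound 4, and none goes against this. Nothing available accounts for the size of these steps.

On these data alone, it remains open whether the higher number follows the loss of the ring or the carboxy itself. A methyl group or a primary amide at this place would separate the two.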